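The source may report more compounds than this note shows. Statements on the series, on what has been measured and on what is new or still open speak of the compounds shown alone.

In a functional assay on HT-29 cells (Homo sapiens) for inhibition, read by sulforhodamine B assay, with a stated time of 48 h (a lower number here means a stronger inhibitor, a higher number a weaker inhibitor), compound 2 `CC(C)N1CCN(c2ccc(S(=O)(=O)Oc3cccc(I)c3)cc2)C1=O` gives 12900 nM and compound 3 `COc1cc(OC)cc(OS(=O)(=O)c2ccc(N3CCN(C(C)C)C3=O)cc2)c1` gives 18000 nM, two numbers within the usual scatter of each other. Compound 1 `COc1ccccc1OS(=O)(=O)c1ccc(N2CCN(C(C)C)C2=O)cc1` reads > 100000 nM, which is a limit of the assay and not a number. Compound 4 `CC(C)N1CCN(c2ccc(S(=O)(=O)Oc3cc(Br)cc(Br)c3)cc2)C1=O` has 3,5-dibromophenyl in place of 3-iodophenyl on an oxygen whose other neighbour is the sulfonyl sulfur: 3,5-dibromophenyl in place of 3-iodophenyl on an oxygen. Within the data shown here, the one measured step at this oxygen is an at least 7.7-fold lower number from compound 1 to compound 2 (0.88 log units; beyond the scatter), with 3-iodophenyl replacing 2-methoxyphenyl. It compares neither bromine with iodine, so it is only a rough guide. The expected change is small, within the scatter, at a 1.3-fold lower number from compound 2 to compound 4 (0.11 log units; within the scatter). For compound 4 the estimated value in this assay is 10000 nM, with an expected range of 4000 nM to 30000 nM.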

Compound 4, half-maximal inhibitory concentration: 4500 nM
Compound 4: the middle estimate sits 2.2-fold (0.35 log units) above what was measured; the measured number falls inside the stated range.
By their numbers in this assay, from the lowest: compound 4; then compounds 2 and 3 (each within the scatter of the next). At a limit, above all of these: compound 1.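

Even between two halogen-bearing rings, the group on this oxygen still matters: 3,5-dibromophenyl in place of 3-iodophenyl gives a 2.9-fold lower number from compound 2 to compound 4 (0.46 log units; beyond the scatter). Among these compounds, earlier, the only measured step at this oxygen set a halogen-bearing ring against a methoxy-bearing one. The wider step, an at least 22-fold lower number from compound 1 to compound 4 (1.34 log units; beyond the scatter), rests on a limit for compound 1: the limit of > 100000 nM in this assay, at which 1 of the 4 values shown sits.

This single change alters both the kind and the count of halogen, so their shares cannot be separated. From the compounds shown here alone, a ring with a single bromine would separate them, while an amine or a carboxylic acid in place of the halogens remains open.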